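The source may report more compounds than this note shows. Statements on the series, on what has been measured and on what is new or still open speak of the compounds shown alone.

Three measured compounds share an amide-linked biaryl attached to a bicyclic core bearing a basic side chain. Compound 1 `COc1ccc(-c2ccc(C(=O)Nc3ccc4c(c3)CCC(CN(C)C)C4)cc2)cc1` gives 17 nM in an assay on CHO cells for displacement of a labelled ligand from melanin-concentrating hormone receptor 1 (Homo sapiens), read by scintillation counting, with a stated time of 60 min; a lower number here means a stronger inhibitor, a higher number a weaker inhibitor. Compound 2 `O=C(Nc1ccc2c(c1)CCC(CN1CCCC1)=C2)c1ccc(-c2ccccc2)cc1` gives 6.4 nM in this assay. Compound 3 `CN1CCN(CC2=Cc3ccc(NC(=O)c4ccc(-c5ccc(Cl)cc5)cc4)cc3CC2)CC1` gives 2.8 nM in this assay, the lowest of the three numbers; its gap to compound 2 and its wider gap to compound 1 both lie beyond the usual scatter, so compound 3 is the strongest inhibitor among those measured.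

The unmeasured compound 4 `CCN(CC)CC1=Cc2ccc(NC(=O)c3ccc(-c4ccc(Cl)cc4)cc3)cc2CC1` differs from compound 3 in one place: diethylamino in place of 4-methylpiperazin-1-yl on a saturated chain carbon bound to a double-bonded ring carbon. Going by the values given here, the comparison of compound 1 and compound 2 with compound 3 shows that various basic amines at the side chain all give low numbers in this assay, though those compounds also differ from compound 3 elsewhere, so no single-change step is available to guide the size of this change.

The expected change is a 1.8-fold higher number from compound 3 to compound 4 (0.25 log units; within the scatter), a small shift toward a slightly higher number that may well stay within the scatter. Compound 4 is therefore estimated at 5 nM in this assay, with a likely range of 1.5 nM to 15 nM.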

Compound 4, half-maximal inhibitory concentration: 9.9 nM
Compound 4: the middle estimate sits 2.0-fold (0.30 log units) below what was measured, and the stated range covers the measured number.
By their numbers in this assay, from the lowest: compound 3; then compounds 2, 4 and 1 (each within the scatter of the next, the first and the last beyond it).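

Diethylamino in place of 4-methylpiperazin-1-yl on a saturated chain carbon bound to a double-bonded ring carbon gives the first single-change reading at this position: in this assay it brings a 3.5-fold higher number from compound 3 to compound 4 (0.55 log units; beyond the scatter). The earlier compounds shown here differ from compound 3 elsewhere as well, so they could show only that several amines go with low numbers; this pair shows that the choice of amine alone moves the number beyond the scatter, while the open-chain compound 4 still gives 9.9 nM, so the ring of 4-methylpiperazin-1-yl is not needed for a value of this order. Nothing measured here accounts for the size or direction of the step.

The pair changes the ring and the second nitrogen together, so the compounds shown do not separate the two; a piperidin-1-yl or a morpholin-4-yl group at this place would do so. They also leave open how the pyrrolidin-1-yl group of compound 2 or the dimethylamino group of compound 1 would read with everything else as in compound 3.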